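Pyrimidinyl for thiazolyl on the ring nitrogen of compound 3

A few compounds are considered here, and "the series" means these few. Any claim that something is new, unique, unknown or untested is made for them only; others in the source may bear on it.

Compound 1 `O=C(Nc1ccc(Cl)c(F)c1)C1=CCN(c2ncccc2Cl)CC1`: 78 nM
Compound 2 `CC(C)(C)c1ccc(NC(=O)C2=CCN(c3ccccn3)CC2)cc1`: 27 nM
Compound 3 `O=C(Nc1ccc(S(=O)(=O)C(F)(F)F)cc1)C1=CCN(c2nccs2)CC1`: 95 nM

Of the compounds shown here, three share a core and have been measured in an in vitro functional assay on 1321-N1 cells for antagonist activity at transient receptor potential cation channel subfamily V member 1 (Homo sapiens), read by FLIPR and calcium flux; a higher number here means a weaker inhibitor, a lower number a stronger inhibitor. Compound 3 carries the highest of the three numbers. Compound 1 sits nearest to it, and the gap between compound 3 and compound 1 lies within the scatter, so the two cannot be placed in an order. Compound 2 lies furthest from compound 3, with a lower number, and that gap lies beyond the scatter.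

Compound 4 `O=C(Nc1ccc(S(=O)(=O)C(F)(F)F)cc1)C1=CCN(c2ncccn2)CC1` has not yet been measured. It differs from compound 3 in one place: pyrimidin-2-yl in place of 1,3-thiazol-2-yl on an amine nitrogen in a ring. Both groups carry no donor and two acceptors, and each is an aromatic ring with two hetero atoms, the ring growing from five to six members.

Among the compounds with values here, no step between measured compounds isolates such a swap, so no measured step guides the expectation. Compound 4 is estimated to give 110 nM in this assay, with a range from 40 nM to 300 nM. The expected step of a 1.2-fold higher number from compound 3 to compound 4 (0.06 log units; within the scatter) lies within the scatter, in no clear direction.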

Compound 4, half-maximal inhibitory concentration: 44 nM
Estimate against measurement, compound 4: 2.5-fold (0.40 log units) above, and the stated range covers the measured number.
By their numbers in this assay, from the lowest: compounds 2, 4, 1 and 3 (each within the scatter of the next, the first and the last beyond it).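

In this assay, within the data shown here, pyrimidin-2-yl in place of 1,3-thiazol-2-yl on the amine nitrogen in the ring gives a 2.2-fold lower number from compound 3 to compound 4 (0.33 log units; beyond the scatter), the first change in this set that can be read at a single place. It shows that the number responds to this ring even when the count of donors and acceptors stays the same, with the six-membered ring giving the lower number here. No measurement at hand accounts for the step, and ring size and ring atoms change together in this one swap, so their shares cannot be separated.

On these data alone, it remains open whether the same swap would give a similar step with the amide aryl groups of compound 1 or compound 2. Also open, as far as these compounds go, is how a plain phenyl ring, or a pyrimidin-2-yl carrying an amine, would fare on this nitrogen.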